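Aryl variation on the ring nitrogen: notes toward compound 4

A few compounds are considered here, and "the series" means these few. Any claim that something is new, unique, unknown or untested is made for them only; others in the source may bear on it.

Measured so far:
compound 1 `COc1ccccc1N1C(=O)CSC1C(=O)NCCCCc1ccccc1` — in a functional assay on HOS-TE85 cells (Homo sapiens) for inhibition, read by CCK-8 assay, with a stated time of 72 h, tested at 1 uM (on this read-out lower numbers stand for less inhibition and higher numbers for more inhibition at the one concentration tested (going by the name of the read-out)), compound 1 gives 0%
compound 2 `O=C(NCCCCc1ccccc1)c1cccc(C2SCC(=O)N2c2ccccc2)c1` — compound 2 gives 96%
compound 3 `Cc1cccc(N2C(=O)CSC2c2cccc(C(=O)NCCCCc3ccccc3)c2)c1` — compound 3 gives 96%

Compound 3 stands level with compound 2 at the digits shown, and the two together are the highest of the three numbers; its nearest neighbour is compound 2, its furthest compound 1, which lies far lower. Among the measured compounds shown here, the one single-change step measured, no change at the digits printed from compound 2 to compound 3 (within the scatter), shows that a methyl on the aryl attached to the ring nitrogen leaves the read-out untouched.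

Compound 4 `COc1cccc(OC)c1N1C(=O)CSC1c1cccc(C(=O)NCCCCc2ccccc2)c1` differs from compound 3 by 2,6-dimethoxyphenyl in place of 3-methylphenyl on an amide-type nitrogen in a ring. For the measured compounds named here, no measured step places a methoxy on that aryl alone; compound 1 carries one there but differs from compound 3 in more than one place, so only its number can be compared: compound 1 gives 0% against compound 3 at 96%. The bearing step, no change at the digits printed from compound 2 to compound 3 (within the scatter), shows the number left level by substitution on this aryl, while the unexplained low number of compound 1 argues for a wide range downward. Compound 4 is therefore expected at 60%, with a range of 10% to 97%. The expected step of a number 36 percentage points lower from compound 3 to compound 4 (beyond the scatter) is a moderate fall, with much uncertainty.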

Compound 4, a percentage reported as inhibition, at one concentration (the size of the read-out at that concentration, not a potency): 95%
Estimate against measurement, compound 4: 35 percentage points below; the range from low to high includes it.
By their numbers in this assay, from the lowest: compound 1; then compounds 4, 2 and 3 (each within the scatter of the next).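

In this assay the entry of 2,6-dimethoxyphenyl on the amide-type nitrogen in the ring gives a number 1 percentage points lower from compound 3 to compound 4 (within the scatter) and likewise a number 1 percentage points lower from compound 2 to compound 4 (within the scatter) with phenyl as the group that leaves. Until now this position had been probed only with a methyl on the aryl; it now also holds its number with a group of 10 heavy atoms and 2 hydrogen-bond acceptors in place of 3-methylphenyl with 7 heavy atoms and 0 acceptors, so on the shared core of compounds 2, 3 and 4 two methoxy groups on this aryl do not lower the read-out beyond the scatter. Nothing at hand gives a reason why this position accepts the change.

Open, going by these compounds, is whether the number would also hold with an amine or a carboxylic acid on this aryl, or with a saturated ring such as cyclohexyl in place of the aryl on that nitrogen. Compound 1 differs from compounds 2, 3 and 4 in more than one place, so what separates its number from theirs stays unresolved, and a read-out at one concentration gives no potency by which compounds 2, 3 and 4 could be told apart.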